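A few compounds are considered here, and "the series" means these few. Any claim that something is new, unique, unknown or untested is made for them only; others in the source may bear on it.

Measured compounds:
compound 1 `Oc1ccc(-c2cc(-c3cccnc3)nc(-c3ccccc3Cl)c2)cc1`, 0.9%
compound 2 `Oc1ccc(-c2cc(-c3cccc(Cl)c3)nc(-c3ccccn3)c2)cc1`, 59.4%
compound 3 `Oc1cccc(-c2cc(-c3ccc(Cl)cc3)nc(-c3cccs3)c2)c1`, 15.1%

In an assay on isolated protein for inhibition of DNA topoisomerase 1 (Homo sapiens), with a stated time of 30 min, tested at 100 uM (on this read-out higher numbers stand for a stronger effect at the one concentration tested and lower numbers for a weaker effect), compound 3 gives 15.1%. This places compound 3 second highest of the three numbers: compound 1 sits lower with 0.9%, a gap beyond the usual scatter, while compound 2 sits much higher with 59.4%, a gap also beyond the scatter. Compound 4 `Oc1cccc(-c2cc(-c3ccc(Cl)cc3)nc(-c3ccccn3)c2)c1` has not been measured. It differs from compound 3 in one place: pyridin-2-yl in place of thiophen-2-yl on an aromatic carbon. For the measured compounds named here, no measured pair differs in only this one place, so the size of this change cannot be read off directly. Compound 2 also carries a pyridin-2-yl group and gives a higher number than compound 3, but compound 2 differs from compound 3 in other places as well, so that comparison is only a loose hint. The expected step is a number 14.9 percentage points higher from compound 3 to compound 4 (beyond the scatter) in this assay, a moderate rise. Compound 4 is estimated at 30%, with a range from 5% to 65%.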

Compound 4, a percentage reported as inhibition, at one concentration (the size of the read-out at that concentration, not a potency): 30%
Estimate against measurement, compound 4: no gap at the digits printed, within the range that was stated.
By their numbers in this assay, from the lowest: compound 1; then compound 3; then compound 4; then compound 2.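

In this assay, for the compounds shown here, pyridin-2-yl in place of thiophen-2-yl on the aromatic carbon next to the ring nitrogen gives a number 14.9 percentage points higher from compound 3 to compound 4 (beyond the scatter), the first change at this position whose size can be read from a pair differing in one place only. The 3-hydroxyphenyl and 4-chlorophenyl groups stay the same, and the count of hydrogen-bond acceptors in the swapped group also stays the same, so the step belongs to exchanging a five-membered sulfur-containing ring for a six-membered nitrogen-containing one. No measurement shown here explains why the number rises.

This single pair leaves open how a plain phenyl ring, or a pyridine ring carrying an amine, would behave at this position. It also leaves open whether the same exchange would give a similar step with the other groups on the core changed.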